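The compounds below may be only part of what the source reports. "The series", "measured", "known", "first", "only" and "open" are said of these compounds alone.

Among the compounds with values here, compound 2 `N#Cc1ccc(-c2cc(COC(Cc3cn(C4CCN(Cc5ccc([N+](=O)[O-])cc5)CC4)nn3)c3ccc(Br)cc3)on2)cc1` is one of two compounds measured in a functional assay on Caco-2 cells (Homo sapiens) for cytotoxicity, with a stated time of 48 h; a higher number here means a weaker inhibitor, a lower number a stronger inhibitor; in this assay compound 2 gives 2000 nM, while compound 1 `COc1ccc(-c2cc(COC(Cc3cn(C4CCN(Cc5ccc([N+](=O)[O-])cc5)CC4)nn3)c3ccc(Br)cc3)on2)cc1` gives 3000 nM. Within the data shown here, the single measured step, a 1.5-fold lower number from compound 1 to compound 2 (0.18 log units; within the scatter), lies within the scatter. Compound 3 `O=[N+]([O-])c1ccc(CN2CCC(n3cc(CC(OCc4cc(-c5ccccc5Br)no4)c4ccc(Br)cc4)nn3)CC2)cc1` carries a further change at the same aromatic carbon: 2-bromophenyl in place of 4-cyanophenyl on an aromatic carbon. Among the measured compounds shown here, no measured step involves a 2-bromophenyl, so the one earlier swap at this carbon is the only guide, and it was small. A step within the scatter is therefore expected, a 1.3-fold higher number from compound 2 to compound 3 (0.10 log units; within the scatter). Compound 3 is estimated at 2500 nM, in the range 1000 nM to 6000 nM.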

Compound 3, half-maximal inhibitory concentration: 3000 nM
Compound 3: the middle estimate sits 1.2-fold (0.08 log units) below what was measured; the measured number falls inside the stated range.
By their numbers in this assay, from the lowest: compounds 2, 1 and 3 (each within the scatter of the next).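

In this assay the aromatic carbon next to the ring nitrogen now carries a third aryl group with no step beyond the scatter: the swap from 4-cyanophenyl gives a 1.5-fold higher number from compound 2 to compound 3 (0.18 log units; within the scatter) and the swap from 4-methoxyphenyl gives no change at the digits printed from compound 1 to compound 3 (within the scatter). A substituent in the 2-position of the phenyl ring, and a bromine at that, thus separates from neither 4-substituted compound. No evidence bears on this flat result. On these data alone, whether a pyridine, a carboxylic acid or an aliphatic amine at this carbon would move the number beyond the scatter stays open.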